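Aryl change at the chain carbon: compound 3 to compound 4

The source may report more compounds than this note shows. Statements on the series, on what has been measured and on what is new or still open speak of the compounds shown alone.

The series shares a thioether-bearing enone core, seen in compound 1 `COc1cc(/C=C(/SCc2ccc(Br)cc2)C(=O)c2ccc(Br)cc2)cc([N+](=O)[O-])c1O`, compound 2 `COc1ccccc1/C=C(/SCc1ccc(Cl)c(Cl)c1)C(=O)c1ccc(Cl)cc1` and compound 3 `O=C(/C(=C\c1ccc(O)c(C(=O)O)c1)SCc1ccc(Br)cc1)c1ccc(Br)cc1`. In a functional assay on DU-145 cells (Homo sapiens) for inhibition, read by trypan blue exclusion, with a stated time of 96 h (a lower number here means a stronger inhibitor of growth, a higher number a weaker inhibitor of growth), compound 1 gives 25000 nM, compound 2 gives 10000 nM and compound 3 gives 10000 nM. Compound 3 is level with compound 2 at the digits recorded, the two together giving the lowest numbers of the three; compound 1 gives a higher number, and that gap lies beyond the scatter.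

Compound 4 `O=C(/C(=C\c1cc(I)c(O)c(I)c1)SCc1ccc(Br)cc1)c1ccc(Br)cc1` has not yet been measured in this assay. It differs from compound 3 in one place: 4-hydroxy-3,5-diiodophenyl in place of 3-carboxy-4-hydroxyphenyl on a double-bonded chain carbon bound to a double-bonded chain carbon. Going by the values given here, no measured pair in the set isolates this kind of change, so there is no step on record to lean on. The three measured numbers sit close together, and the change keeps the aryl ring on the same chain carbon. The expectation is therefore a step from compound 3 to compound 4 of a 1.2-fold higher number from compound 3 to compound 4 (0.08 log units; within the scatter), within the scatter, in no firm direction. Compound 4 is thus estimated at 12000 nM in this assay, with a range from 4000 nM to 35000 nM.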

Compound 4, concentration for 50% growth inhibition: 1000 nM
The estimate for compound 4 lay 12-fold (1.08 log units) above the measured number, and the stated range ends above it.
By their numbers in this assay, from the lowest: compound 4; then compounds 2 and 3 (each within the scatter of the next); then compound 1.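

The aryl group on a double-bonded chain carbon bound to a double-bonded chain carbon is not a silent position in this assay: 4-hydroxy-3,5-diiodophenyl in place of 3-carboxy-4-hydroxyphenyl gives a 10-fold lower number from compound 3 to compound 4 (1.00 log units; beyond the scatter), beyond the scatter. Going by these compounds alone, the earlier compounds differ from one another in more than one place, so they could not tie any change in growth inhibition to this position; this pair is the first to do so. Nothing on record accounts for the size of this step.

The pair swaps the carboxylic acid and the two iodines together, so the contribution of each remains unresolved. Also open, as far as these compounds go, are how a single iodine or an amine on this ring would read, and whether the step carries over to other groups on the shared core.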